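Series notes: compound 4 before its measurement

The compounds below may be only part of what the source reports. "The series", "measured", "known", "first", "only" and "open" are said of these compounds alone.

Measured in an assay on isolated protein for inhibition of GMP reductase 2 (Homo sapiens), read by spectrophotometry; on this read-out lower numbers stand for stronger inhibition and higher numbers for weaker inhibition:
compound 1, `C[C@H](Oc1cccc(Cl)c1Cl)C(=O)Nc1ccc2oc(-c3ccc(OC(F)(F)F)cc3)nc2c1`: > 5000 nM
compound 2, `COc1ccc(Cc2nc3cc(NC(=O)[C@H](C)Oc4cccc(Cl)c4Cl)ccc3o2)cc1`: > 5000 nM
compound 3, `C[C@H](Oc1cccc(Cl)c1Cl)C(=O)Nc1ccc2oc(C3=CC=NCC3=O)nc2c1`: > 5000 nM

The value of compound 1 is a limit of this assay and not a number. The value of compound 2 is likewise a limit. The value of compound 3 is a limit as well, so compound 3 stands only at a limit, with no number of its own. All three sit together at the limit of > 5000 nM in this assay, at which 3 of the 3 values shown sit. The measured steps are a step that the two limits leave unreadable from compound 1 to compound 2, a step that the two limits leave unreadable from compound 1 to compound 3 and a step that the two limits leave unreadable from compound 2 to compound 3; none of them can be given a size or a direction, so none bears readably on the change to come.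

Compound 4, `C[C@H](Oc1cccc(Cl)c1Cl)C(=O)Nc1ccc2oc(-c3ccc(O)cc3)nc2c1`, is not yet measured in this assay. It differs from compound 3 by a group of 7 heavy atoms (6 carbon, 1 oxygen; one six-membered aromatic ring of carbon only) in place of a group of 7 heavy atoms (5 carbon, 1 nitrogen, 1 oxygen; one six-membered non-aromatic ring with 1 hetero atom), on an aromatic carbon. Among the compounds with values here, with no readable step available, no step of any particular size or direction is expected in this assay; the expectation is only that compound 4 most likely again sits at a limit. Compound 4 is estimated at 8000 nM, between 2000 nM and 30000 nM, which means an expected step that the limit leaves unreadable from compound 3 to compound 4.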

Compound 4, inhibition constant: > 5000 nM
Compound 4 ended at the assay's limit; the forecaster's own chance of this, stated with the estimate: 75%; the middle value is on the limit's open side.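

In this assay compound 4 gives > 5000 nM, a limit and not a number, so its steps to compound 1, compound 2 and compound 3 cannot be read. The series stays where it was: the limit of > 5000 nM in this assay, at which 4 of the 4 values shown sit.

The compounds shown leave open how these four compare with one another and whether any group in this place gives a measurable value.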